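A Single Methyl Step in Cell Tolerance

This account rests on a few compounds, and the source may have more. Where it says the series, first, only, none or still open, it means among the compounds named here.

Compound 1: `Cc1cc2occ(CN(C)CCN(C)Cc3cn(S(=O)(=O)c4ccccc4)c4ccccc34)c(=O)c2cc1C` — in an ADME assay on BMMC cells (Mus musculus) for cytotoxicity, read by MTT assay, with a stated time of 48 h (a higher number here means that more compound is tolerated, a lower number that less compound is tolerated), compound 1 gives "not determined" (no result reported).
Compound 2: `CN(CCN(C)Cc1cn(S(=O)(=O)c2ccccc2)c2ccccc12)Cc1coc2ccccc2c1=O` — 58500 nM.

In this assay compound 2 gives 58500 nM. For the measured compounds named here, this is the only number available; compound 1 was tested but no result was reported for it, so compound 2 cannot be placed against any second value, and no step between two measured compounds exists.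

Compound 3 `Cc1ccc2c(=O)c(CN(C)CCN(C)Cc3cn(S(=O)(=O)c4ccccc4)c4ccccc34)coc2c1` differs from compound 2 by methyl in place of hydrogen on an aromatic carbon, that is, a methyl in place of hydrogen on an aromatic carbon of the shared core. Going by the values given here, with no measured step to draw on, nothing in the available data points to a shift in either direction, and the step from compound 2 to compound 3 in this assay is expected to stay within the usual scatter of repeated measurements.

Compound 3 is therefore estimated at 50000 nM in this assay, with a range of 22000 nM to 110000 nM, corresponding to an expected step of a 1.2-fold lower number from compound 2 to compound 3 (0.07 log units; within the scatter).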

Compound 3, concentration lethal to 50% of the cells: < 20000 nM
Compound 3: no number, only a limit; the forecaster's own chance of this, stated with the estimate: 10%; middle value at least 2.5-fold (0.39 log units) away from the limit.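

In this assay, for the compounds shown here, a methyl in place of hydrogen on an aromatic carbon gives an at least 2.9-fold lower number from compound 2 to compound 3 (0.46 log units; beyond the scatter), the first measured step, and it shows that this place on the shared core is not silent: less compound is tolerated once the methyl is present. Compound 3 gives < 20000 nM, which is a limit of the assay and not a number. The size of the step therefore stays unfixed, and only its direction and its lower bound can be read: the limit of < 20000 nM in this assay, at which 1 of the 3 values shown sits.

Compound 1 has no reported result, so what a second methyl on the core would add cannot be read. Going by these compounds, it also remains open whether a longer chain such as ethyl, an amine or a carboxylic acid at this place would shift tolerance the same way.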